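Azetidine for piperidine at the aminomethyl chain

A few compounds are considered here, and "the series" means these few. Any claim that something is new, unique, unknown or untested is made for them only; others in the source may bear on it.

Measured so far:
compound 1 `Nc1cccc(CNc2cc(C(F)(F)F)cc3[nH]ncc23)c1` gives 24%
compound 2 `O=[N+]([O-])c1ccc(Cl)cc1CNc1cc(C(F)(F)F)cc2[nH]ncc12` gives 35%
compound 3 `FC(F)(F)c1cc(NC[C@H]2CCCCN2)c2cn[nH]c2c1` gives 19%

All three numbers come from an assay for inhibition of Indoleamine 2,3-dioxygenase 1 (Homo sapiens), with stated times of 10 min and 60 min, tested at 10 uM; a lower number here means a weaker effect, a higher number a stronger effect of the compound at the concentration tested. Compound 3 and compound 1 lie within the scatter of each other: the step of a number 5 percentage points lower from compound 1 to compound 3 (within the scatter) says nothing beyond noise. Compound 2 stands beyond the scatter from compound 3, the only gap here that counts as a real difference.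

Compound 4 `FC(F)(F)c1cc(NCC2CNC2)c2cn[nH]c2c1` is not yet measured. It differs from compound 3 in one place: azetidin-3-yl in place of piperidin-2-yl on a saturated chain carbon bound to a nitrogen on an aromatic ring.

Among the measured compounds shown here, no measured step bears directly on this change. The one step that touches the same place, piperidin-2-yl in place of 3-aminophenyl, fell within the scatter, so the chain substituent has shown no effect so far in this series. For the measured compounds named here, compound 2 sits higher, but no step to it is computed, so its number offers no guide for compound 4. On this basis the expected step of a number 1 percentage points higher from compound 3 to compound 4 (within the scatter) is none beyond the scatter. Compound 4 is therefore estimated at 20%, with a range from 5% to 38%.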

Compound 4, a percentage reported as inhibition, at one concentration (the size of the read-out at that concentration, not a potency): 10%
Compound 4: middle estimate off by 10 percentage points, on the high side; the measured number falls inside the stated range.
By their numbers in this assay, from the lowest: compounds 4, 3 and 1 (each within the scatter of the next, the first and the last beyond it); then compound 2.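

In this assay, exchanging the six-membered ring for the four-membered one gives a number 9 percentage points lower from compound 3 to compound 4 (within the scatter), so the two saturated amine rings are not separated at this place on the chain. Among the compounds shown here, the comparison with the aromatic group gives a number 14 percentage points lower from compound 1 to compound 4 (beyond the scatter), the first step at this place to lie beyond the scatter, although it is modest and compound 3 stays within the scatter of both compound 1 and compound 4. No supporting data bear on why these groups give these numbers.

On these data alone, a pyrrolidin-3-yl group remains open at this place, as does the opposite stereocentre in the piperidin-2-yl group. Also open, as far as these compounds go, is whether a methyl or acetyl group on the azetidine nitrogen would shift the number for compound 4.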